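This account rests on a few compounds, and the source may have more. Where it says the series, first, only, none or still open, it means among the compounds named here.

Measured compounds:
compound 1 `COc1ccc([C@@H]2CC(=O)c3c(O)cc(OCc4cn(Cc5ccccc5C(F)(F)F)nn4)cc3O2)cc1O`: 12500 nM
compound 2 `COc1ccc([C@@H]2CC(=O)c3c(O)cc(OCc4cn(Cc5ccccc5F)nn4)cc3O2)cc1O`: 7320 nM
compound 3 `COc1ccc([C@@H]2CC(=O)c3c(O)cc(OCc4cn(Cc5ccccc5Cl)nn4)cc3O2)cc1O`: 6140 nM

In a functional assay on RAW264.7 cells (Mus musculus) for inhibition, read by Griess assay, with stated times of 2 h and 24 h (a lower number here means a stronger inhibitor, a higher number a weaker inhibitor), compound 1 gives 12500 nM, the highest of the three numbers and therefore the weakest inhibitor among them. Its nearest neighbour is compound 2, reached by a 1.7-fold lower number from compound 1 to compound 2 (0.23 log units; within the scatter); compound 3 lies furthest, reached by a 2.0-fold lower number from compound 1 to compound 3 (0.31 log units; beyond the scatter), a modest gain. Between the two neighbours themselves the step is a 1.2-fold lower number from compound 2 to compound 3 (0.08 log units; within the scatter).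

Compound 4 `COc1ccc([C@@H]2CC(=O)c3c(O)cc(OCc4cn(C5CCCCC5)nn4)cc3O2)cc1O` has not yet been tested. It differs from compound 1 by cyclohexyl in place of 2-(trifluoromethyl)benzyl on an aromatic nitrogen. The three measured steps all change only the substituent on the benzyl ring and keep that ring in place; none removes the benzyl group or puts a non-aromatic ring on the triazole nitrogen. They therefore bear only indirectly on this change, and what they show is that the numbers move little across the set. Among the measured compounds shown here, no measured step gives a direction for the exchange in compound 4, so the expectation is a number near that of compound 1, with a wide range: the expected step is a 1.1-fold lower number from compound 1 to compound 4 (0.06 log units; within the scatter). Compound 4 is estimated at 11000 nM, between 4000 nM and 30000 nM.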

Compound 4, half-maximal inhibitory concentration: 15600 nM
The estimate for compound 4 lay 1.4-fold (0.15 log units) below the measured number; measured number inside the range.
By their numbers in this assay, from the lowest: compounds 3, 2, 1 and 4 (each within the scatter of the next, the first and the last beyond it).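

In this assay a non-aromatic ring on this nitrogen of the five-membered ring still gives a measurable inhibitor, and putting cyclohexyl in place of 2-(trifluoromethyl)benzyl gives a 1.2-fold higher number from compound 1 to compound 4 (0.10 log units; within the scatter) and so cannot be told from no change. Set against the other two benzyl groups, the same cyclohexyl does stand apart, with a 2.5-fold higher number from compound 3 to compound 4 (0.40 log units; beyond the scatter) and a 2.1-fold higher number from compound 2 to compound 4 (0.33 log units; beyond the scatter) as modest steps, so what this exchange does depends on which benzyl group it replaces. Nothing available explains these differences.

Cyclohexyl differs from each benzyl group in more than one way at once, so the part played by the aromatic ring stays unresolved. A plain benzyl, a cyclohexylmethyl group or a longer alkyl chain on the same nitrogen would be needed to separate those parts.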